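Adding an isobutyl to a proline-linked aziridine dicarboxylate

This account rests on a few compounds, and the source may have more. Where it says the series, first, only, none or still open, it means among the compounds named here.

Three related compounds have been tested in a functional assay on J774 cells (Mus musculus) for cytotoxicity, with a stated time of 48 h; a lower number here means a stronger inhibitor, a higher number a weaker inhibitor. Compound 1, with the structure `CC(C)(C)OC(=O)NCC(=O)N1CCC[C@@H]1C(=O)N1[C@H](C(=O)OCc2ccccc2)[C@H]1C(=O)OCc1ccccc1`, reaches only the limit of the assay, giving > 100000 nM. Compound 2, `CCOC(=O)[C@@H]1[C@@H](C(=O)OCC)N1C(=O)[C@@H]1CCCN(C(=O)[C@H](CC(C)C)NC(=O)OC(C)(C)C)C1`, likewise stops at the assay limit with > 100000 nM. Compound 3, `CC(C)C[C@H](NC(=O)OC(C)(C)C)C(=O)N1CC[C@@H]1C(=O)N1[C@H](C(=O)OCc2ccccc2)[C@H]1C(=O)OCc1ccccc1`, is the only one of the three with a numerical result, giving 37200 nM. Within the data shown here, compound 1 therefore stands among the two values that sit at the limit, as noted in the limit of > 100000 nM in this assay, at which 2 of the 3 values shown sit, and no step between measured compounds is available to calibrate any change.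

The new compound, compound 4, has the structure `CC(C)C[C@@H](NC(=O)OC(C)(C)C)C(=O)N1CCC[C@@H]1C(=O)N1[C@H](C(=O)OCc2ccccc2)[C@H]1C(=O)OCc1ccccc1`. It differs from compound 1 by one change: isobutyl in place of hydrogen on a saturated chain carbon bound to an amide-type nitrogen and a carbonyl carbon. Among the measured compounds shown here, with no measured step to lean on, the expectation from compound 1 to compound 4 is an at least 1.6-fold lower number from compound 1 to compound 4 (0.22 log units; that floor lies within the scatter), a gain that may or may not exceed the usual scatter. Compound 4 is accordingly estimated at 60000 nM, within a range from 20000 nM to 200000 nM, with a real chance that the assay again reports only a limit.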

Compound 4, half-maximal inhibitory concentration: > 100000 nM
Compound 4: a limit, no number (the forecaster's own chance of this, stated with the estimate: 45%); middle value at least 1.6-fold (0.22 log units) from the limit.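

Among these compounds, compound 1 and compound 4 both end at a limit of the assay rather than a number, so the swap of hydrogen for isobutyl gives no step that can be read: the limit of > 100000 nM in this assay, at which 3 of the 4 values shown sit. Going by these compounds, whether that isobutyl changes the cytotoxicity at all, and by how much, stays open.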